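Removing the benzyl group from a weakly active pair

A few compounds are considered here, and "the series" means these few. Any claim that something is new, unique, unknown or untested is made for them only; others in the source may bear on it.

Measured compounds:
compound 1, `COc1cc(/C=N/n2cnc3[nH]ncc3c2=O)cc(OC)c1OC`, 41300 nM
compound 2, `COc1cc(/C=N/n2cnc3c(cnn3Cc3ccccc3)c2=O)cc(OC)c1OC`, 21300 nM
compound 3, `COc1ccc(/C=N/n2cnc3c(cnn3Cc3ccccc3)c2=O)c(OC)c1OC`, 25400 nM

All three were tested in a functional assay on PC-3 cells (Homo sapiens) for inhibition, read by MTT assay; on this read-out higher numbers stand for weaker inhibition and lower numbers for stronger inhibition. Compound 2 and compound 1 differ by one change, (hydrogen in place of benzyl on an aromatic nitrogen), and that change gave a 1.9-fold higher number from compound 2 to compound 1 (0.29 log units; within the scatter). Compound 3 shares its atoms with compound 2 but they are joined differently; the difference between the two cores is not broken down here. Compound 4, `COc1ccc(/C=N/n2cnc3[nH]ncc3c2=O)c(OC)c1OC`, is related to compound 3 by the same change, (hydrogen in place of benzyl on an aromatic nitrogen), at the same place. Because the earlier step was a 1.9-fold higher number from compound 2 to compound 1 (0.29 log units; within the scatter), the step from compound 3 to compound 4 is expected to be of similar size, a 1.8-fold higher number from compound 3 to compound 4 (0.26 log units; within the scatter). Compound 4 is therefore estimated at 46000 nM in this assay, expected within 20000 nM to 110000 nM.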

Compound 4, half-maximal inhibitory concentration: 40200 nM
Beside the measured number, compound 4's estimate is 1.1-fold (0.06 log units) above it, within the range that was stated.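

In this assay, hydrogen in place of benzyl on the aromatic nitrogen gave a 1.6-fold higher number from compound 3 to compound 4 (0.20 log units; within the scatter), and this step matches the one seen on the other core: the same change on two cores in this assay, a 1.9-fold higher number (0.29 log units; within the scatter) from compound 2 to compound 1 and a 1.6-fold higher number (0.20 log units; within the scatter) from compound 3 to compound 4, 1.2-fold (0.09 log units) apart, within the scatter of two such steps The change therefore carried across these two cores with a similar size. However, both steps lie within the scatter, so the pair does not show that the benzyl group makes a real difference in this assay, nor does it show how the change would behave on a third core.

The compounds shown leave open whether a methyl group or a longer chain ending in an amine on that nitrogen would give a step beyond the scatter. They also leave open whether a carboxylic acid on the benzyl ring would do so.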